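Phenyl substitution pattern at the amide of an aryl amide series

This account rests on a few compounds, and the source may have more. Where it says the series, first, only, none or still open, it means among the compounds named here.

Compound 1 `O=C(Nc1ccc(Cl)c(-c2nnc3c(Cl)cccn23)c1)c1ccccn1` carries a pyridin-2-yl on the carbonyl carbon. In a functional assay on MDA-MB-468 cells (Homo sapiens) for antiproliferative activity, read by MTT assay, with a stated time of 72 h (a higher number here means a weaker inhibitor, a lower number a stronger inhibitor), compound 1 gives only a limit, > 100000 nM, not a number. For the measured compounds named here, compound 2 `Cc1cc(Cl)ccc1C(=O)Nc1ccc(Cl)c(-c2nnc3c(Cl)cccn23)c1`, with a 4-chloro-2-methylphenyl in that place, gives 34300 nM in this assay, the only number in the set; the step of an at least 2.9-fold lower number from compound 1 to compound 2 (0.46 log units; beyond the scatter) is therefore bounded by the limit of > 100000 nM in this assay, at which 1 of the 2 values shown sits. Compound 3 `O=C(Nc1ccc(Cl)c(-c2nnc3c(Cl)cccn23)c1)c1c(F)cccc1Cl` changes the same position: 2-chloro-6-fluorophenyl in place of 4-chloro-2-methylphenyl on a carbonyl carbon. Going by the values given here, no measured step compares two substituted phenyl groups with each other, so the single step from compound 1 to compound 2 offers no direct guide. He therefore expects compound 3 to stay near compound 2, the expected step being a 1.2-fold higher number from compound 2 to compound 3 (0.07 log units; within the scatter), not beyond the scatter. His estimate for compound 3 in this assay is 40000 nM, expected to lie between 12000 nM and 130000 nM.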

Compound 3, half-maximal inhibitory concentration: 57600 nM
Estimate against measurement, compound 3: 1.4-fold (0.16 log units) below; low and high end bracket the measured number.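

In this assay, for the compounds shown here, the first direct comparison of two substituted phenyl groups on this carbonyl carbon gives a 1.7-fold higher number from compound 2 to compound 3 (0.23 log units; within the scatter), so 2-chloro-6-fluorophenyl and 4-chloro-2-methylphenyl cannot be told apart here, although their substituents differ. The comparison with pyridin-2-yl gives an at least 1.7-fold lower number from compound 1 to compound 3 (0.23 log units; that floor lies within the scatter), so compound 3 is not shown to differ from compound 1, unlike compound 2, whose step from compound 1 has a floor beyond the scatter. Compound 1 gives a limit, not a number: the limit of > 100000 nM in this assay, at which 1 of the 3 values shown sits.

On these data alone, it remains open whether a group of another kind on the phenyl ring, such as an amine or a carboxylic acid, would move the number beyond the scatter. Also open, as far as these compounds go, is how an unsubstituted phenyl or a longer alkyl chain on the carbonyl carbon would compare.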